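The source may report more compounds than this note shows. Statements on the series, on what has been measured and on what is new or still open speak of the compounds shown alone.

The measured compounds in an ADME assay on MT4 cells (Homo sapiens) for cytotoxicity, with a stated time of 5 days; a lower number here means that less compound is tolerated, a higher number that more compound is tolerated:

compound 1 `CC(C)(C)C#Cc1cc(N(C(=O)[C@H]2CC[C@H](C)CC2)[C@H]2CC[C@H](Oc3cccnc3)CC2)c(C(=O)O)s1` — in this assay compound 1 gives > 20000 nM, which is a limit of the assay and not a number.
compound 2 `CC(C)N(C(=O)C1CCC(F)(F)CC1)c1cc(C#CC(C)(C)C)sc1C(=O)O` — compound 2 gives > 20000 nM, again a limit.
compound 3 `CC(C)N(C(=O)[C@H]1[C@@H]2CCCC[C@@H]21)c1cc(C#CC(C)(C)C)sc1C(=O)O` — compound 3 gives > 20000 nM, also a limit.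

All three values therefore sit at the same limit (the limit of > 20000 nM in this assay, at which 3 of the 3 values shown sit), and compound 1 stands nowhere in particular among them: it has a limit, and so have the two others. Going by the values given here, the only step between measured compounds that differ in one place, a step that the two limits leave unreadable from compound 2 to compound 3, is unreadable because both ends are limits.

Compound 4 `CC(C)(C)C#Cc1cc(N(C(=O)[C@H]2CC[C@H](C)CC2)[C@H]2CC[C@H](O)CC2)c(C(=O)O)s1` is not yet measured. It differs from compound 1 by hydrogen in place of pyridin-3-yl on an oxygen on a saturated carbon. No measured step bears on this change; the one step that is shown, from compound 2 to compound 3, concerns a different place and is unreadable anyway. With every measured value at the limit, nothing points to a readable step in either direction for this change. Compound 4 is expected to give 30000 nM, within 15000 nM to 100000 nM. The step from compound 1 that this estimate means, a step that the limit leaves unreadable from compound 1 to compound 4, is expected to be nothing beyond the scatter, and most likely compound 4 will again be reported only as a limit.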

Compound 4, half-maximal cytotoxic concentration: > 20000 nM
Compound 4: no number, only a limit; the forecaster's own chance of this, stated with the estimate: 85%; the middle value lies beyond the limit too.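

In this assay, no step can be read from the change of (pyridin-3-yl)oxy to hydroxy between compound 1 and compound 4, because both values are limits and not numbers: the limit of > 20000 nM in this assay, at which 4 of the 4 values shown sit.

The compounds shown leave open at what concentration any of them reaches half-maximal cytotoxicity, and whether this change alters it.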